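This account rests on a few compounds, and the source may have more. Where it says the series, first, only, none or still open, it means among the compounds named here.

Of the compounds shown here, two have been tested in a functional assay on K562 cells (Homo sapiens), read by MTT assay, with a stated time of 72 h (on this read-out higher numbers stand for weaker inhibition and lower numbers for stronger inhibition), and neither gave a number. Compound 1 `CNc1ncnc2c1c(-c1ccsc1)cn2[C@@H]1O[C@H](CO)[C@@H](O)[C@H]1O` reached only the assay limit of > 20000 nM. Compound 2 `Nc1nc(N)c2c(-c3ccco3)cn([C@@H]3O[C@H](CO)[C@@H](O)[C@H]3O)c2n1` also reached only a limit, > 20000 nM. Both readings therefore sit at the same boundary: the limit of > 20000 nM in this assay, at which 2 of the 2 values shown sit. Neither compound can be ranked against the other, and compound 2 has no exact value from which to measure a change.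

Compound 3 `Nc1nc(N)c2c(-c3cccs3)cn([C@@H]3O[C@H](CO)[C@@H](O)[C@H]3O)c2n1` is compound 2 with thiophen-2-yl in place of furan-2-yl on an aromatic carbon. The two groups match in what is counted for them, apart from the exchange of oxygen for sulfur. For the measured compounds named here, no measured step between two closely related compounds is available in this assay to indicate how much such an exchange matters. The estimated step of an at least 1.3-fold lower number from compound 2 to compound 3 (0.12 log units; that floor lies within the scatter) is expected to remain within the usual scatter, with at most a slight shift towards stronger inhibition. Compound 3 is expected to give about 15000 nM, within an estimated range of 4000 nM to 20000 nM, and it may well reach the limit too.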

Compound 3, half-maximal inhibitory concentration: > 20000 nM
Compound 3: no number, only a limit; the forecaster's own chance of this, stated with the estimate: 65%; at least 1.3-fold (0.12 log units) between middle value and limit.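

In this assay compound 3 gives > 20000 nM as a limit and not a number. For the compounds shown here, compound 2 also stands at a limit, so no step from compound 2 to compound 3 can be read, and all readings share one boundary: the limit of > 20000 nM in this assay, at which 3 of the 3 values shown sit. The compounds shown leave open whether thiophen-2-yl and furan-2-yl differ at all on this read-out.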